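A few compounds are considered here, and "the series" means these few. Any claim that something is new, unique, unknown or untested is made for them only; others in the source may bear on it.

Measured so far:
Compound 1 `CC(C)N(Cc1cccc(OCCCCCC(=O)O)c1)C(=O)c1ccc(-c2cccc(OCc3ccccc3)c2)cc1`: in an ADME assay on HEK293 cells (Homo sapiens) for cytotoxicity, read by CellTiter-Glo and resazurin assay, with a stated time of 72 h (on this read-out higher numbers stand for an effect only at larger amounts of compound and lower numbers for an effect already at smaller amounts), compound 1 gives > 26000 nM, a limit of the assay rather than a number.
Compound 2 `COc1cc(OC)cc(-c2ccc(C(=O)N(Cc3cccc(OCCCCCC(=O)O)c3)C(C)C)cc2)c1`: in this assay compound 2 gives > 26000 nM, likewise a limit.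

Compound 2 thus stands at the limit of > 26000 nM in this assay, at which 2 of the 2 values shown sit; both values shown sit there, and no number separates the two compounds. Compound 3 `CC(C)N(Cc1cccc(OCCCCCC(=O)O)c1)C(=O)c1ccc(-c2cccc(O)c2)cc1` carries the change (3-hydroxyphenyl in place of 3,5-dimethoxyphenyl on an aromatic carbon), 3-hydroxyphenyl in place of 3,5-dimethoxyphenyl on an aromatic carbon. Among the measured compounds shown here, no measured step covers this change. The expected step that the limit leaves unreadable from compound 2 to compound 3 lies within the scatter, in no particular direction. Compound 3 is expected near 30000 nM, between 12000 nM and 80000 nM, most likely reported again only as a limit.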

Compound 3, half-maximal effective concentration: > 26000 nM
Compound 3: a limit, no number; the forecaster's own chance of this, stated with the estimate: 85%; the middle value lies beyond the limit too.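

In this assay compound 3 gives > 26000 nM, a limit, so no step to it from compound 1 or compound 2 can be read: the limit of > 26000 nM in this assay, at which 3 of the 3 values shown sit.

The compounds shown leave open at what concentration any of them would register here, and whether swapping 3,5-dimethoxyphenyl for 3-hydroxyphenyl changes that.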